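Dichloro Swap on a Sulfonamide Already at the Assay Limit

A few compounds are considered here, and "the series" means these few. Any claim that something is new, unique, unknown or untested is made for them only; others in the source may bear on it.

Compound 2 `O=S(=O)(NC1=NCCN1C(=S)SN1CCn2c1nsc2=S)c1ccc(Br)cc1` is judged in a functional assay on KYSE-510 cells (Homo sapiens) for antiproliferative activity, read by crystal violet staining, with a stated time of 96 h; on this read-out higher numbers stand for weaker inhibition of growth and lower numbers for stronger inhibition of growth. In this assay compound 2 gives only >= 20000 nM, which is a limit of the assay and not a number. Compound 1 `Cc1ccc(S(=O)(=O)NC2=NCCN2C(=S)SN2CCn3c2nsc3=S)cc1` has the same kind of result. In this assay compound 1 gives >= 20000 nM, again a limit rather than a number. The step between them, a step that the two limits leave unreadable from compound 1 to compound 2, therefore cannot be read. Compound 3 `O=S(=O)(NC1=NCCN1C(=S)SN1CCn2c1nsc2=S)c1ccc(Cl)c(Cl)c1` differs from compound 2 by 3,4-dichlorophenyl in place of 4-bromophenyl on a sulfonyl sulfur. Within the data shown here, the only measured step, a step that the two limits leave unreadable from compound 1 to compound 2, bears on this change but offers no size and no direction, and the limit of >= 20000 nM in this assay, at which 2 of the 2 values shown sit, shows that both known values rest at the same limit. No movement beyond the scatter is therefore expected in this assay, and a further limit is the most likely outcome. Compound 3 is accordingly expected to give about 20000 nM in this assay, with a range from 6000 nM to 60000 nM. The expected step of a number no higher from compound 2 to compound 3 (the limit leaves the size open) is thus essentially none.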

Compound 3, concentration for 50% growth inhibition: >= 20000 nM
Compound 3: no number, only a limit (the forecaster's own chance of this, stated with the estimate: 80%); the middle value sits exactly at the limit.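

No new step can be read among compound 1, compound 2 and compound 3, since each result in this assay is a limit of the assay and not a number: the limit of >= 20000 nM in this assay, at which 3 of the 3 values shown sit.

The compounds shown leave open whether 4-methylphenyl, 4-bromophenyl and 3,4-dichlorophenyl on the sulfonyl sulfur differ at all in their effect on growth.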